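The source may report more compounds than this note shows. Statements on the series, on what has been measured and on what is new or still open speak of the compounds shown alone.

Compound 3 `CC(C)(C)OC(=O)N1CCN(C(=S)SCc2cn(Cc3ccc(Cl)cc3)nn2)CC1` gives the lowest number of the three measured compounds in a functional assay on MGC-803 cells (Homo sapiens) for inhibition, read by MTT assay, with a stated time of 72 h (on this read-out lower numbers stand for stronger inhibition and higher numbers for weaker inhibition), at 9790 nM. Compound 2 `CC(C)(C)OC(=O)N1CCN(C(=S)SCc2cn(Cc3ccc(Cl)c(Cl)c3)nn2)CC1` gives 33700 nM in this assay, and compound 1 `COc1ccc(-n2cc(CSC(=S)N3CCN(C(=O)OC(C)(C)C)CC3)nn2)cc1` gives 87300 nM. The steps are a 2.6-fold lower number from compound 1 to compound 2 (0.41 log units; beyond the scatter), an 8.9-fold lower number from compound 1 to compound 3 (0.95 log units; beyond the scatter) and a 3.4-fold lower number from compound 2 to compound 3 (0.54 log units; beyond the scatter). Compound 4 `CC(C)(C)OC(=O)N1CCN(C(=S)SCc2cn(Cc3ccccc3Cl)nn2)CC1` differs from compound 3 by 2-chlorophenyl in place of 4-chlorophenyl on a saturated chain carbon bound to an aromatic nitrogen. Among the measured compounds shown here, none of the measured steps moves a chloro around the benzyl ring; the nearest guidance comes from the step from compound 2 to compound 3, where a chloro leaves rather than relocates, and from the steps from compound 1, which change the whole group on the aromatic nitrogen. For the measured compounds named here, with no direct precedent, the chloro kept and the shared core unchanged, the expectation for this assay is a step of about a 1.3-fold higher number from compound 3 to compound 4 (0.12 log units; within the scatter), not clearly beyond the scatter. Compound 4 is therefore estimated at 13000 nM, within a range from 4000 nM to 45000 nM.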

Compound 4, half-maximal inhibitory concentration: 490 nM
The estimate for compound 4 lay 27-fold (1.42 log units) above the measured number; the measured number lies below the stated range.
By their numbers in this assay, from the lowest: compound 4; then compound 3; then compound 2; then compound 1.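

In this assay, relocating the chloro on the benzyl ring, with the same atoms and the shared core unchanged, gives a 20-fold lower number from compound 3 to compound 4 (1.30 log units; beyond the scatter), so this position depends strongly on where the chloro sits and not only on which group is present. Among the compounds shown here, the 2-chlorobenzyl group also stands well clear of the other two groups on the aromatic nitrogen, with a 69-fold lower number from compound 2 to compound 4 (1.84 log units; beyond the scatter) and a 180-fold lower number from compound 1 to compound 4 (2.25 log units; beyond the scatter), both larger than any step among the earlier compounds. Nothing available explains why this relocation has so large an effect.

On these data alone, it remains open whether the low number depends on the chloro itself or would persist with a bromo or a methyl group in its place on the benzyl ring. As far as these compounds go, how a plain benzyl group would compare with the 2-chlorobenzyl group also remains open, as does whether the same order would hold on other cell lines.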